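Methyl on the phenyl of compound 2: compound 4

This account rests on a few compounds, and the source may have more. Where it says the series, first, only, none or still open, it means among the compounds named here.

The shared core is held by three measured compounds. Compound 1 `Cc1ccc(NC(=O)/C=C/c2ccccc2)c(C(N)=O)c1` gives 65.4% in a functional assay on K562 cells (Homo sapiens) for antiproliferative activity, read by trypan blue exclusion, with a stated time of 48 h, tested at 10 uM; on this read-out lower numbers stand for less inhibition of growth and higher numbers for more inhibition of growth at the one concentration tested. Compound 2 `NC(=O)c1cc(Br)ccc1NC(=O)/C=C/c1ccccc1` gives 62.4% in this assay, and compound 3 `Cc1ccccc1/C=C/C(=O)Nc1ccc(Br)cc1C(N)=O` gives 43.2% in this assay. Among the three numbers compound 2 stands second highest: one step around it is a number 3 percentage points lower from compound 1 to compound 2 (within the scatter), and the other is a number 19.2 percentage points lower from compound 2 to compound 3 (beyond the scatter).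

Compound 4 `Cc1ccc(/C=C/C(=O)Nc2ccc(Br)cc2C(N)=O)cc1` follows; its change from compound 2 is methyl in place of hydrogen on an aromatic carbon. Within the data shown here, one measured step bears on it in kind, the step of a number 19.2 percentage points lower from compound 2 to compound 3 (beyond the scatter), in which a methyl also entered an aromatic carbon of the phenyl of the cinnamoyl part, though not the carbon named here. The step of a number 3 percentage points lower from compound 1 to compound 2 (within the scatter) concerns the other ring and a bromo, and says nothing of a methyl entering the phenyl. Resting on that single step, the expectation for compound 4 in this assay is a loss of modest size, with a range wide enough to reach into the scatter. Compound 4 is therefore estimated at 52%, between 36% and 68%. That estimate means a step of a number 10.4 percentage points lower from compound 2 to compound 4 (beyond the scatter) is expected.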

Compound 4, percent growth inhibition at one concentration: 45.9%
Compound 4: the middle estimate sits 6.1 percentage points above what was measured; low and high end bracket the measured number.
By their numbers in this assay, from the lowest: compounds 3 and 4 (each within the scatter of the next); then compounds 2 and 1 (each within the scatter of the next).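

In this assay, the change from phenyl to 4-methylphenyl gives a number 16.5 percentage points lower from compound 2 to compound 4 (beyond the scatter), so a methyl on the aromatic carbon para to a large group also lowers growth inhibition, and the earlier loss, a number 19.2 percentage points lower from compound 2 to compound 3 (beyond the scatter), was not confined to the 2-methylphenyl compound. Moving the methyl gives a number 2.7 percentage points higher from compound 3 to compound 4 (within the scatter), so in this assay the two methylphenyl compounds cannot be told apart, and both stand apart from the unsubstituted phenyl of compound 2. The data shown offer no measurement that explains the loss from either methyl.

The compounds shown leave open whether the loss belongs to methyl alone or to any group on this ring, since no methoxy, chloro, hydroxyl or longer chain such as ethyl stands at this carbon. Going by these compounds, both methylphenyl compounds also carry the bromo on the other ring, so it remains open whether the same loss would appear with the methyl of compound 1 on that ring.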